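This account rests on a few compounds, and the source may have more. Where it says the series, first, only, none or still open, it means among the compounds named here.

Measured so far in a physicochemical assay for solubility; on this read-out higher numbers stand for higher solubility and lower numbers for lower solubility:

- Compound 1 `CNC(=O)c1cc(C(=O)NC2CC2)cn([C@H](C)c2ccccc2)c1=O`: >= 168 ug/mL
- Compound 2 `CNC(=O)c1cc(C(=O)NC2CC2)cn(CC2CCCCC2)c1=O`: >= 148 ug/mL
- Compound 3 `CNC(=O)c1cc(C(=O)NC)c(=O)n(Cc2ccccc2)c1`: >= 118 ug/mL

All three readings are limits of the assay rather than numbers. Compound 2 therefore has only a limit, >= 148 ug/mL, and its place among the three cannot be ranked.

The next compound to be measured is compound 4 `CNC(=O)c1cc(C(=O)NC2CC2)cn(Cc2cccc3[nH]ncc23)c1=O`. It differs from compound 2 at a single place: 1H-indazol-4-yl in place of cyclohexyl on a saturated chain carbon bound to an aromatic nitrogen. In words, 1H-indazol-4-yl stands in place of cyclohexyl on a saturated chain carbon bound to an aromatic nitrogen.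

Within the data shown here, the one measured step at this part of the structure is a step that the two limits leave unreadable from compound 1 to compound 2. Both of its ends are limits, so it offers no size to carry over. Among the measured compounds shown here, none of the measured compounds contains 1H-indazol-4-yl, so there is no direct precedent for this change either. Only a broad expectation is possible: a step downward, or none that can be read.

The expected change in this assay is an at least 1.4-fold lower number from compound 2 to compound 4 (0.17 log units; that floor lies within the scatter), an estimate held loosely. For compound 4 the estimated value is 100 ug/mL, with an expected range from 25 ug/mL to 200 ug/mL.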

Compound 4, solubility: 10 ug/mL
The estimate for compound 4 lay 10-fold (1.00 log units) above the measured number, outside the stated range (below it).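

In this assay, among these compounds, the group on a saturated chain carbon bound to an aromatic nitrogen proves able to move the read-out: 1H-indazol-4-yl in place of cyclohexyl gives an at least 14-fold lower number from compound 2 to compound 4 (1.17 log units; beyond the scatter), the only step here with a readable size. Among the compounds shown here, the earlier compounds could not show this, as each of them gave only a limit of the assay and the one step among them cannot be read. The size of the new step is itself only a floor, since the value for compound 2 is a limit and not a number: the limit of >= 148 ug/mL in this assay, at which 1 of the 4 values shown sits.

The compounds shown do not separate which part of this exchange goes with the step, whether the two aromatic rings that replace a non-aromatic ring of carbon only, the two ring nitrogens, or the added hydrogen-bond donor. They also leave open whether an amine or a carboxylic acid in place of 1H-indazol-4-yl would give a number in this assay or another limit.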